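The compounds below may be only part of what the source reports. "The series", "measured", "known", "first", "only" and "open" are said of these compounds alone.

Measured so far:
Compound 1 `C#CCNC1CCc2c(SCCc3cccc(C)c3)cccc21`, 0.35 nM.
Compound 2 `C#CCNC1CCc2c(SCCc3cccc(Br)c3)cccc21`, 30500 nM.
Compound 3 `C#CCNC1CCc2c(SCCc3cccc(OC)c3)cccc21`, 28700 nM.

In an assay on isolated protein for inhibition of Amine oxidase [flavin-containing] B (Homo sapiens) (on this read-out higher numbers stand for weaker inhibition and lower numbers for stronger inhibition), compound 3 stands second highest of the three numbers; its nearest neighbour is compound 2, with a 1.1-fold lower number from compound 2 to compound 3 (0.03 log units; within the scatter), while compound 1 lies far away, with an 82000-fold higher number from compound 1 to compound 3 (4.91 log units; beyond the scatter). Compound 4 `C#CCNC1CCc2c(SCCc3ccc(F)c(F)c3)cccc21` differs from compound 3 by 3,4-difluorophenyl in place of 3-methoxyphenyl on a saturated chain carbon, two bonds along the chain from a sulfur. The step that bears most directly on this is the swap of one aromatic substituent for another between compound 2 and compound 3, which stayed within the scatter; the large steps of an 87000-fold higher number from compound 1 to compound 2 (4.94 log units; beyond the scatter) and an 82000-fold higher number from compound 1 to compound 3 (4.91 log units; beyond the scatter) show that only the methyl analogue stands out. For compound 4 the expected step is therefore a 1.9-fold lower number from compound 3 to compound 4 (0.28 log units; within the scatter), and compound 4 is estimated at 15000 nM, within 1000 nM to 100000 nM.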

Compound 4, half-maximal inhibitory concentration: 3240 nM
Estimate against measurement, compound 4: 4.6-fold (0.67 log units) above, and the stated range covers the measured number.
By their numbers in this assay, from the lowest: compound 1; then compound 4; then compounds 3 and 2 (each within the scatter of the next).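

In this assay the 3,4-difluorophenyl group gives a change beyond the scatter among the compounds far from compound 1, with an 8.9-fold lower number from compound 3 to compound 4 (0.95 log units; beyond the scatter) and a 9.4-fold lower number from compound 2 to compound 4 (0.97 log units; beyond the scatter). This position therefore separates groups other than the methyl-bearing one, though still only modestly, while a 9300-fold higher number from compound 1 to compound 4 (3.97 log units; beyond the scatter) leaves compound 1 well apart from the rest. Nothing available explains these differences. Open, on these data alone, is whether a single fluorine on the ring would do as well as two, and whether ethyl or trifluoromethyl in place of the methyl of compound 1 would keep its low number.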